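This account rests on a few compounds, and the source may have more. Where it says the series, first, only, none or still open, it means among the compounds named here.

Measured so far:
- compound 1 `ClCc1cccc(Cn2cnc3c(Cl)nc(Cl)nc32)c1`: 2040 nM
- compound 2 `ClCc1ccccc1Cn1cnc2ncnc(Cl)c21`: 3630 nM
- compound 3 `ClCc1ccc(Cn2cnc3c(Cl)nc(Cl)nc32)cc1`: 1740 nM

Of the compounds shown here, three have been tested in a functional assay on MCF7 cells (Homo sapiens) for cytotoxicity, read by sulforhodamine B assay, with a stated time of 48 h; a higher number here means a weaker inhibitor of growth, a lower number a stronger inhibitor of growth. Compound 2 stands with the highest of the three numbers. Its nearest neighbour is compound 1, whose number is lower by a margin that falls within the usual scatter, so the two cannot be told apart. Compound 3 lies further off, with a number lower than that of compound 2 by a margin beyond the scatter. Among the compounds with values here, no two of the three measured compounds differ in a single place, so no step between them can be read directly.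

Compound 4 `ClCc1ccccc1Cn1cnc2nc(Cl)nc(Cl)c21` has not yet been measured. It differs from compound 2 by a single change: chloro in place of hydrogen on an aromatic carbon. Compounds 1 and 3 carry the same pair of chloro groups on the shared core as compound 4 does, but their benzyl groups differ from that of compound 2, so they give no clean guide to this step.

Within the data shown here, with no comparable step among the measured compounds, the expected step from compound 2 to compound 4 in this assay is small, a 1.4-fold lower number from compound 2 to compound 4 (0.14 log units; within the scatter), with no direction that can be claimed beyond the scatter. Compound 4 is therefore estimated at 2600 nM, within a range from 1200 nM to 5500 nM.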

Compound 4, concentration for 50% growth inhibition: 1040 nM
Beside the measured number, compound 4's estimate is 2.5-fold (0.40 log units) above it, outside the stated range (below it).
By their numbers in this assay, from the lowest: compounds 4, 3, 1 and 2 (each within the scatter of the next, the first and the last beyond it).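

In this assay, chloro in place of hydrogen on an aromatic carbon of the shared core, at the place between two ring nitrogen atoms, gives a 3.5-fold lower number from compound 2 to compound 4 (0.54 log units; beyond the scatter). This is the first step among these compounds that can be read directly, and it shows that, with the benzyl group held the same, this position is not indifferent to substitution: the added chloro goes with stronger growth inhibition by a modest margin that lies beyond the scatter. Nothing available explains why this single atom changes the number.

On these data alone, whether the same step would hold with the differently placed chloromethyl groups on the benzyl rings of compound 1 and compound 3 remains open, since neither has a partner here that differs from it only at this position. Also open is whether the effect is particular to chloro or would extend to other groups at this place, such as an amine, a methoxy group or a methyl group, as the single step shown cannot separate these possibilities.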